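This account rests on a few compounds, and the source may have more. Where it says the series, first, only, none or still open, it means among the compounds named here.

Measured so far:
compound 1, `COc1cc(C)nc2n/c(=N/C(=O)c3c(-c4ccc(Cl)cc4Cl)noc3C)sn12`, 80.6%
compound 2, `COc1cc(SC)nc(NC(=S)NC(=O)c2c(-c3ccc(Cl)cc3Cl)noc2C)n1`, 69.2%

Two compounds have been run in a functional assay on the whole organism for inhibition, with Brassica napus as the target, with a stated time of 72 h, tested at 100 mg/L; a higher number here means more inhibition of growth at the concentration tested, a lower number less inhibition of growth. Compound 1 gives 80.6%, and compound 2 gives 69.2%. Compound 2 therefore holds the lower of the two numbers, and the gap to compound 1 lies beyond the usual scatter of this assay. The two compounds differ in more than one place, so nothing is known about what any single change does.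

Compound 3, `COc1cc(OC)nc(NC(=S)NC(=O)c2c(-c3ccc(Cl)cc3Cl)noc2C)n1`, is the next compound and has not yet been measured. It differs from compound 2 in one place: methoxy in place of methylsulfanyl on an aromatic carbon. One of the two groups on that aromatic carbon is exchanged for another of the same size and with the same count of hydrogen-bond acceptors. Among the compounds with values here, no measured pair in this set reports what such an exchange does in this assay, so the step is expected to be small, with no preferred direction, and to stay within the scatter; the expected step from compound 2 to compound 3 is a number 3.2 percentage points lower from compound 2 to compound 3 (within the scatter). Compound 3 is accordingly estimated to give 66% in this assay, within a range from 45% to 85%.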

Compound 3, percent growth inhibition at one concentration: 70.8%
Compound 3: middle estimate off by 4.8 percentage points, on the low side; the measured number falls inside the stated range.
By their numbers in this assay, from the lowest: compounds 2, 3 and 1 (each within the scatter of the next, the first and the last beyond it).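

Methoxy in place of methylsulfanyl on this aromatic carbon, next to the ring nitrogen, turns the 4-methoxy-6-(methylsulfanyl)pyrimidin-2-yl group into 4,6-dimethoxypyrimidin-2-yl, and in this assay this is the one single change that can be read, at a number 1.6 percentage points higher from compound 2 to compound 3 (within the scatter) for that exchange. At this position, then, the two groups cannot be told apart by percent growth inhibition, so for this pair the choice between an oxygen-linked and a sulfur-linked methyl group leaves the read-out within its usual scatter. Nothing further is available that bears on why the two groups read alike.

The steps to compound 1 cannot be read, as it differs from compound 2 and from compound 3 in more than one place. Going by these compounds, it remains open whether a group of another kind on this aromatic carbon, such as an amine, a chlorine atom or a longer chain like butoxy, would move the number in this assay beyond the scatter, or whether this position tolerates such exchanges as it does the one seen here.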